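Trifluoromethyl to nitro on the aryl urea series

The source may hold more compounds than are shown below. What is called first, only, known or untested is meant among the compounds shown, and "the series" means these compounds.

compound 1 `Nc1ccc(NC(=O)NCCCCC(c2ccc(F)cc2)c2ccc(F)cc2)cc1` - > 20000 nM (a limit, not a number)
compound 2 `CC(=O)Nc1ccc(NC(=O)NCCCCC(c2ccc(F)cc2)c2ccc(F)cc2)cc1` - > 20000 nM (a limit, not a number)
compound 3 `O=C(NCCCCC(c1ccc(F)cc1)c1ccc(F)cc1)Nc1cccc(C(F)(F)F)c1` - 3380 nM
compound 4 `O=C(NCCCCC(c1ccc(F)cc1)c1ccc(F)cc1)Nc1cccc([N+](=O)[O-])c1` - not yet measured

Among the measured compounds shown here, in a functional assay on MDA-MB-231 cells (Homo sapiens) for cytotoxicity, read by MTT assay, with a stated time of 48 h (on this read-out higher numbers stand for weaker inhibition and lower numbers for stronger inhibition), compound 3 gives 3380 nM, the only true number. Compound 1 and compound 2 stand at the limit of > 20000 nM in this assay, at which 2 of the 3 values shown sit, and so give no number to rank against.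

The change under consideration is nitro in place of trifluoromethyl on an aromatic carbon. Nitro takes the place of trifluoromethyl on an aromatic carbon, meta to a large group, and the rest of the structure stays the same.

For the measured compounds named here, no measured step makes this exchange directly. The nearest evidence is the replacement of the whole aryl group on the amide-type nitrogen, seen in an at least 5.9-fold lower number from compound 1 to compound 3 (0.77 log units; beyond the scatter) and in an at least 5.9-fold lower number from compound 2 to compound 3 (0.77 log units; beyond the scatter). Both show that this assay responds to that group, though each is bounded by a limit on one side. The step that the two limits leave unreadable from compound 1 to compound 2 has no readable size.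

With the substituent position unchanged, the expected step is small, towards a higher number and close to the scatter: a 1.3-fold higher number from compound 3 to compound 4 (0.12 log units; within the scatter) (estimated). Compound 4 is estimated at 4500 nM, with an expected range from 1800 nM to 12000 nM.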

Compound 4, half-maximal inhibitory concentration: 3790 nM
Beside the measured number, compound 4's estimate is 1.2-fold (0.07 log units) above it, and the stated range covers the measured number.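

In this assay, nitro in place of trifluoromethyl on an aromatic carbon gives a 1.1-fold higher number from compound 3 to compound 4 (0.05 log units; within the scatter) and so leaves compound 3 and compound 4 level, although nitro brings 2 hydrogen-bond acceptors and trifluoromethyl brings 0. A readable number at this place is therefore no longer tied to trifluoromethyl alone, and 3-nitrophenyl separates from the two other aryl groups in the same way as 3-(trifluoromethyl)phenyl, with an at least 5.2-fold lower number from compound 1 to compound 4 (0.72 log units; beyond the scatter) and with an at least 5.2-fold lower number from compound 2 to compound 4 (0.72 log units; beyond the scatter) as the two steps. Both steps are bounded on one side, since compound 1 and compound 2 each stand at a limit and not at a number: the limit of > 20000 nM in this assay, at which 2 of the 4 values shown sit.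

The step between compound 1 and compound 2 cannot be read, and each of their steps to compound 4 changes both the group and its place on the ring, so the contribution of place stays unseparated from that of the group. Also open, as far as these compounds go, is whether a nitrile, a carboxylic acid or a methoxy group on the same aromatic carbon would stay level with compound 3 and compound 4, or whether nitro would give the same reading elsewhere on the ring.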